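Compound 4: nitro in place of methyl

A few compounds are considered here, and "the series" means these few. Any claim that something is new, unique, unknown or untested is made for them only; others in the source may bear on it.

In an ADME assay on HEK293 cells (Homo sapiens) for cytotoxicity (on this read-out higher numbers stand for weaker inhibition and lower numbers for stronger inhibition), compound 1 `CCCCCCCCCCCCCCNC(=O)[C@H](CO)/N=C/c1cccc(C)c1` gives 51100 nM and stands within the scatter of the other two measured compounds. Compound 2 `CCCCCCCCCCCCCCNC(=O)[C@H](CO)/N=C/c1ccccc1O` gives 80800 nM on this read-out and compound 3 `CCCCCCCCCCCCCCNC(=O)[C@H](CO)/N=C/c1ccc(Cl)cc1` gives 77700 nM on it, so the three values show no order.

Compound 4 `CCCCCCCCCCCCCCNC(=O)[C@H](CO)/N=C/c1cccc([N+](=O)[O-])c1` is not yet measured. It keeps the core of compound 1 and carries nitro in place of methyl on an aromatic carbon in a position meta to a large group.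

Among the compounds with values here, three measured steps bear on this change: a 1.6-fold higher number from compound 1 to compound 2 (0.20 log units; within the scatter) and a 1.5-fold higher number from compound 1 to compound 3 (0.18 log units; within the scatter) and also a 1.0-fold lower number from compound 2 to compound 3 (0.02 log units; within the scatter) in the same part of the structure. All three lie within the scatter. Within the data shown here, no measured compound carries nitro, so this reading is an extrapolation. No step beyond the scatter is expected in this assay, and the estimated step is a 1.3-fold higher number from compound 1 to compound 4 (0.12 log units; within the scatter) only. Compound 4 is expected at 68000 nM (34000 nM to 130000 nM).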

Compound 4, half-maximal inhibitory concentration: 82700 nM
Compound 4: middle estimate off by 1.2-fold (0.08 log units), on the low side; measured number inside the range.
By their numbers in this assay, from the lowest: compounds 1, 3, 2 and 4 (each within the scatter of the next).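

Nitro in place of methyl on this aromatic carbon, meta to a large group, brings in three heavy atoms for one and two hydrogen-bond acceptors, yet in this assay it gives a 1.6-fold higher number from compound 1 to compound 4 (0.21 log units; within the scatter) and leaves the read-out within the scatter. The comparisons with the other aryl groups give a 1.1-fold higher number from compound 3 to compound 4 (0.03 log units; within the scatter) and a 1.0-fold higher number from compound 2 to compound 4 (0.01 log units; within the scatter) and so place 3-nitrophenyl with 3-methylphenyl, 2-hydroxyphenyl and 4-chlorophenyl, with no order among the four compounds. No measurement shown accounts for this flat result.

From the compounds shown here alone, whether an amine or a carboxylic acid on this aromatic carbon would also stay within the scatter remains open. Going by these compounds, all four compounds share the same core and long chain, so the outcome with a shorter chain is also open.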